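Swapping a Cyanofuran for Methoxyphenyl on a Shared Core

The source may hold more compounds than are shown below. What is called first, only, known or untested is meant among the compounds shown, and "the series" means these compounds.

In a functional assay on CHO-K1 cells for antagonist activity at adenosine receptor A1 (Homo sapiens), read by a beta-galactosidase reporter and cAMP accumulation, with stated times of 15 min and 6 h (a higher number here means a weaker inhibitor, a lower number a stronger inhibitor), compound 2 `N#Cc1ccc(-c2nc(N)c3cc(Cc4ccccc4)sc3n2)o1` gives 3160 nM, the highest number among the three compounds measured. Compound 3 `CC(c1ccccc1)c1cc2c(N)nc(-c3cccc(C#N)c3)nc2s1` gives 1770 nM, a gap from compound 2 that lies within the scatter, whereas compound 1 `COc1ccccc1Cc1cc2c(N)nc(-c3ccc(C)o3)nc2s1` gives 122 nM, a gap that lies well beyond it. Compound 4 `COc1cccc(-c2nc(N)c3cc(Cc4ccccc4)sc3n2)c1` has not yet been measured in this assay. It differs from compound 2 in one place: 3-methoxyphenyl in place of 5-cyanofuran-2-yl on an aromatic carbon. For the measured compounds named here, no single-change step between measured compounds is available, so the size of this change cannot be read from a neighbour. Because compound 1 without a nitrile reaches 122 nM, a move toward lower numbers is expected. The expected step is a 5.3-fold lower number from compound 2 to compound 4 (0.72 log units; beyond the scatter). Compound 4 is expected to give 600 nM, within a range from 150 nM to 2500 nM.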

Compound 4, inhibition constant: 266 nM
Estimate against measurement, compound 4: 2.3-fold (0.35 log units) above; measured number inside the range.
By their numbers in this assay, from the lowest: compound 1; then compound 4; then compounds 3 and 2 (each within the scatter of the next).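

In this assay, for the compounds shown here, 3-methoxyphenyl in place of 5-cyanofuran-2-yl gives a 12-fold lower number from compound 2 to compound 4 (1.07 log units; beyond the scatter), the first direct reading of a change at this position. With the rest of the molecule held constant, the group on this aromatic carbon between two ring nitrogen atoms alone produces a large step on the shared core. No measured evidence here explains the step.

The compounds shown change the ring, the nitrile and the methoxy together, so their separate shares remain open. A plain phenyl or a 3-aminophenyl at this position could begin to separate them.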